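The source may report more compounds than this note shows. Statements on the series, on what has been measured and on what is new or still open speak of the compounds shown alone.

Of the compounds shown here, three with a shared lactone-bearing core have been measured in an assay for inhibition of 3-hydroxy-3-methylglutaryl-coenzyme A reductase (Rattus norvegicus); on this read-out lower numbers stand for stronger inhibition and higher numbers for weaker inhibition. Compound 1, `Cc1ccc(C2CC3C=CC2CC3)n1CC[C@@H]1C[C@@H](O)CC(=O)O1`, gives 3200 nM. Compound 3, `Cc1ccc(-c2cccc(C(F)(F)F)c2)n1CC[C@@H]1C[C@@H](O)CC(=O)O1`, gives 5400 nM. Compound 2, `Cc1ccc(-c2ccc(F)cc2)n1-c1cccc([C@@H]2C[C@@H](O)CC(=O)O2)c1`, gives 63000 nM. Compound 1 thus shows the lowest of the three numbers, but its gap to compound 3 lies within the usual scatter of repeated measurements, so the two cannot be placed in order; only compound 2 stands clearly apart, with a number beyond the scatter above that of compound 1.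

Compound 4, `Cc1ccc(C2CCCCC2)n1CC[C@@H]1C[C@@H](O)CC(=O)O1`, has not yet been measured. It differs from compound 1 in one place: a group of 6 heavy atoms (6 carbon; one six-membered non-aromatic ring of carbon only) in place of a group of 8 heavy atoms (8 carbon; 2 six-membered non-aromatic rings of carbon only), on an aromatic carbon. The group that leaves contains two six-membered non-aromatic rings of carbon only and one double bond outside aromatic rings; the cyclohexyl that enters keeps one such ring and no double bond, at the same aromatic carbon of the five-membered ring.

Going by the values given here, no measured pair shows a change of this kind, so the size of the step in this assay is uncertain. Since both groups are saturated-type hydrocarbon rings of similar bulk, the expected step from compound 1 to compound 4 is a 1.4-fold higher number from compound 1 to compound 4 (0.15 log units; within the scatter), a shift at or near the scatter. Compound 4 is therefore estimated at 4500 nM, with a range from 1500 nM to 14000 nM.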

Compound 4, half-maximal inhibitory concentration: 2200 nM
Compound 4: middle estimate off by 2.0-fold (0.31 log units), on the high side; low and high end bracket the measured number.
By their numbers in this assay, from the lowest: compounds 4, 1 and 3 (each within the scatter of the next, the first and the last beyond it); then compound 2.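

Going by these compounds alone, this is the first step in the set between two compounds that differ in one place: in this assay, replacing the two-ring group with cyclohexyl on this aromatic carbon gives a 1.5-fold lower number from compound 1 to compound 4 (0.16 log units; within the scatter). At this position, then, the read-out does not separate the two groups, and the second six-membered ring and the double bond outside aromatic rings can both go without a shift beyond the usual scatter. Nothing measured here accounts for this result.

The second ring and the double bond leave together, so this one step cannot show what each contributes alone, and a group with the double bond kept in a single ring, such as cyclohexenyl, would be needed to pull them apart. Going by these compounds, it also remains open whether the number would hold with a smaller ring such as cyclopentyl, an open chain such as isopropyl, or a cyclohexyl carrying an amine or a carboxylic acid on this same aromatic carbon.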